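The source may hold more compounds than are shown below. What is called first, only, known or untested is meant among the compounds shown, and "the series" means these compounds.

Working notes on the series. In a functional assay on DLD-1 cells (Homo sapiens) for antiproliferative activity, read by CellTiter-Glo, with a stated time of 72 h (a lower number here means a stronger inhibitor, a higher number a weaker inhibitor), compound 1 `CC1CCN(C2CCN(S(=O)(=O)c3cccc4ccccc34)CC2)CC1` gives 0.65 nM, compound 3 `CC1CCN(C2CCN(S(=O)(=O)c3cc(Br)cc4c3OCC4)CC2)CC1` gives 96 nM, and compound 2 `CC1CCN(C2CCN(S(=O)(=O)c3cccnc3)CC2)CC1` gives 2400 nM. Compound 2 thus stands at the highest number of the three, beyond the scatter from both compound 3 and compound 1. Compound 4 `CCc1ccc(S(=O)(=O)N2CCC(N3CCC(C)CC3)CC2)cc1` has not been measured; it differs from compound 2 in one place: 4-ethylphenyl in place of pyridin-3-yl on a sulfonyl sulfur. Since both other measured compounds sit far below compound 2, compound 1 at 0.65 nM and compound 3 at 96 nM, a large step toward a lower number is expected for compound 4, with the size uncertain. The expected step is an 80-fold lower number from compound 2 to compound 4 (1.90 log units; beyond the scatter). Compound 4 is estimated at 30 nM, in the range 3 nM to 300 nM.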

Compound 4, half-maximal inhibitory concentration: > 5000 nM
Compound 4 gave a limit, no number; the forecaster's own chance of this, stated with the estimate: 2%; at least 160-fold (2.22 log units) between middle value and limit.
By their numbers in this assay, from the lowest: compound 1; then compound 3; then compound 2. At a limit, above all of these: compound 4.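

In this assay, 4-ethylphenyl in place of pyridin-3-yl on a sulfonyl sulfur gives an at least 2.0-fold higher number from compound 2 to compound 4 (0.31 log units; beyond the scatter). Compound 4 gives a limit and not a number: the limit of > 5000 nM in this assay, at which 1 of the 4 values shown sits. This position therefore tolerates a move upward as well as downward, and a six-membered aromatic ring of carbon only on the sulfonyl sulfur does not by itself give a low number.

The compounds shown leave open whether the ethyl chain matters, since plain phenyl is not among them. Also open, going by these compounds, is how an amine or a carboxylic acid in place of that ethyl chain would read.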